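Arylsulfonyl tetralin amines: amide replacement at the side chain

This account rests on a few compounds, and the source may have more. Where it says the series, first, only, none or still open, it means among the compounds named here.

Measured compounds:
compound 1 `Cn1ccc(S(=O)(=O)c2ccc3c(c2)CCC[C@H]3CN)c1` — 7.94 nM
compound 2 `O=S(=O)(c1cccc(F)c1)c1ccc2c(c1)CCC[C@H]2CNCCO` — 0.126 nM

In an assay on isolated protein for displacement of a labelled ligand from 5-hydroxytryptamine receptor 6 (Homo sapiens) (a higher number here means a weaker inhibitor, a lower number a stronger inhibitor), compound 2 gives 0.126 nM, the lowest of the two numbers. Its nearest neighbour is compound 1, which in this assay gives 7.94 nM; the two differ in more than one place, so only the two values themselves can be compared, and the gap lies well beyond the scatter.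

Compound 3 `O=C(CO)NC[C@@H]1CCCc2cc(S(=O)(=O)c3cccc(F)c3)ccc21` has not yet been measured in this assay. It differs from compound 2 in one place: (hydroxymethyl)carbonyl in place of 2-hydroxyethyl on an amine nitrogen. The amine nitrogen that carries the 2-hydroxyethyl group in compound 2 thus carries a (hydroxymethyl)carbonyl group in compound 3.

Among the measured compounds shown here, no measured pair in this set shares this change, so there is no step to lean on. The expectation is that the number for compound 3 will be higher than for compound 2, by a step clearly beyond the scatter, a 200-fold higher number from compound 2 to compound 3 (2.30 log units; beyond the scatter). On that basis compound 3 is estimated at 25 nM, with a range from 2 nM to 300 nM.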

Compound 3, inhibition constant: 0.1 nM
Compound 3: the middle estimate sits 250-fold (2.40 log units) above what was measured; measured number below the stated range.
By their numbers in this assay, from the lowest: compounds 3 and 2 (each within the scatter of the next); then compound 1.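

In this assay, placing (hydroxymethyl)carbonyl instead of 2-hydroxyethyl on the amine nitrogen gives a 1.3-fold lower number from compound 2 to compound 3 (0.10 log units; within the scatter), so the two compounds cannot be told apart in this measurement. Among the compounds shown here, the earlier pair could not show this: compound 1 and compound 2 differ in more than one place, whereas this is the first single-place step in the set and shows that, on the shared core, the number at this nitrogen is kept when a carbonyl enters the side chain. No supporting data bear on why the number is kept through this change.

From the compounds shown here alone, this rests on one step, so it remains open whether the same holds for other groups on this nitrogen, such as a plain acetyl group without the hydroxyl, a longer chain such as 3-hydroxypropyl, or a carboxylic acid. Going by these compounds, it also remains open whether the (hydroxymethyl)carbonyl group would give a similar result on the core of compound 1, which carries a different group on the sulfonyl.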